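A few compounds are considered here, and "the series" means these few. Any claim that something is new, unique, unknown or untested is made for them only; others in the source may bear on it.

In a functional assay on A549 cells (Homo sapiens) for antiproliferative activity, read by MTT assay, with a stated time of 24 h (a higher number here means a weaker inhibitor, a lower number a stronger inhibitor), the measured compounds read as follows:

- Compound 1 `Cc1cccc(NNC(=O)c2cccc(NS(=O)(=O)c3cnc(O)nc3O)c2)c1` gives > 20000 nM as a limit
- Compound 2 `O=C(NNc1ccc(F)cc1)c1cccc(NS(=O)(=O)c2cnc(O)nc2O)c1` gives > 20000 nM as a limit
- Compound 3 `Cc1cccc(NNC(=O)c2ccccc2NS(=O)(=O)c2cnc(O)nc2O)c1` gives > 20000 nM as a limit

Compound 3 therefore has no number, only a limit, shared by the whole set as the limit of > 20000 nM in this assay, at which 3 of the 3 values shown sit, shows. Compound 4 `O=C(NNc1cccc(Cl)c1)c1ccccc1NS(=O)(=O)c1cnc(O)nc1O` carries chloro in place of methyl on an aromatic carbon, meta to a large group, as counted in chloro in place of methyl on an aromatic carbon here. Going by the values given here, the one measured step that bears on this change is a step that the two limits leave unreadable from compound 1 to compound 2 and it offers no size. No step beyond the scatter can therefore be expected in this assay and no direction can be given. The expected change is a step that the limit leaves unreadable from compound 3 to compound 4 at most in name. The estimate for compound 4 is 25000 nM with an expected range from 10000 nM to 50000 nM and a limit is again the likely report.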

Compound 4, half-maximal inhibitory concentration: 5290 nM
Compound 4: middle estimate off by 4.7-fold (0.67 log units), on the high side, and the stated range ends above it.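

In this assay, chloro in place of methyl on an aromatic carbon, meta to a large group, gives an at least 3.7-fold lower number from compound 3 to compound 4 (0.57 log units; beyond the scatter). Going by these compounds alone, this is the first step in the set that can be read, since the earlier step between limits could not be, and it shows that this position can move the result on this core. Compound 4 alone carries a number rather than a limit: the limit of > 20000 nM in this assay, at which 3 of the 4 values shown sit.

On these data alone, whether bromo, methoxy or trifluoromethyl at this place would lower the number too stays open. So does whether 3-chlorophenyl would have the same effect on the core of compound 1.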